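The source may report more compounds than this note shows. Statements on the series, on what has been measured and on what is new or still open speak of the compounds shown alone.

The compounds here share a core built around a nitrile-bearing pyrrolidine amide, and they were examined in an assay on the whole organism (plasma, strain Sprague-Dawley) for inhibition of Dipeptidyl peptidase 4 (Rattus norvegicus), with a stated time of 10 h, at a dose of 1 mg/kg by the oral route; a higher number here means more inhibition at the dose given (going by the name of the read-out), a lower number less inhibition. Compound 1, `N#C[C@@H]1CCCN1C(=O)[C@@H]1C[C@H](C(=O)N2CCCCCCC2)CN1`, carries an eight-membered ring amide; in this assay compound 1 gives "not determined" (no result reported). Compound 2, `CCN(CC)C(=O)[C@@H]1CN[C@H](C(=O)N2CCC[C@H]2C#N)C1`, likewise gives in this assay "not determined" (no result reported). Going by the values given here, the only measured entry is compound 3, `C[C@@H]1N[C@H](C(=O)N2CCC[C@H]2C#N)C[C@@H]1C(=O)N1CCSCC1`, which in this assay gives 85%. Compound 4, `CNC(=O)[C@@H]1CN[C@H](C(=O)N2CCC[C@H]2C#N)C1`, is reached from compound 1 by a single change: a group of 2 heavy atoms (1 carbon, 1 nitrogen; no ring) in place of a group of 8 heavy atoms (7 carbon, 1 nitrogen; one eight-membered non-aromatic ring with 1 hetero atom), on a carbonyl carbon. Among the compounds with values here, since compound 1 has no number, the step to compound 4 cannot be measured against it, and no step between measured compounds is available, so the size and direction of the change in this assay can only be guessed; a modest drop below what compound 3 shows seems more likely than a rise, but a change within the scatter is also possible. For compound 4 in this assay a value of 60% is expected, with a likely range from 25% to 88%.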

Compound 4, a percentage reported as inhibition, in the whole organism at one dose (the size of the read-out at that dose, not a potency): 28%
Beside the measured number, compound 4's estimate is 32 percentage points above it, and the stated range covers the measured number.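

In this assay, going by these compounds alone, compound 1 stands as "not determined" (no result reported) and compound 4 gives 28% so no step from compound 1 to compound 4 can be read. What replacing the eight-membered ring amide with methylamino does to inhibition stays open, and nothing shown points to a cause.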